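Phenoxy in place of (phenylcarbamoyl)amino on the sulfonyl sulfur

This account rests on a few compounds, and the source may have more. Where it says the series, first, only, none or still open, it means among the compounds named here.

In a functional assay with Rattus norvegicus as the target (a higher number here means that more compound is needed for the effect, a lower number that less compound is needed), compound 1 `CCNS(=O)(=O)c1ccc2c(c1)C(n1ccccc1=O)=CC(C)(C)O2` gives 56.2 nM, while compound 2 `CC1(C)C=C(n2ccccc2=O)c2cc(S(=O)(=O)NC(=O)Nc3ccccc3)ccc2O1` gives 1410 nM, the higher of the two numbers. Compound 3 `CC1(C)C=C(n2ccccc2=O)c2cc(S(=O)(=O)Oc3ccccc3)ccc2O1` is still unmeasured and differs from compound 2 by phenoxy in place of (phenylcarbamoyl)amino on a sulfonyl sulfur. Among the measured compounds shown here, one measured step bears on this, the large 25-fold higher number from compound 1 to compound 2 (1.40 log units; beyond the scatter), which introduced the phenylcarbamoyl group now leaving. For the measured compounds named here, with no measured phenoxy example, only a partial return is expected, and the estimated change is a 4.7-fold lower number from compound 2 to compound 3 (0.67 log units; beyond the scatter). Compound 3 is estimated at 300 nM, with an expected range of 70 nM to 1300 nM.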

Compound 3, half-maximal effective concentration: 2.51 nM
For compound 3 the middle estimate is 120-fold (2.08 log units) above the measured one, and the stated range ends above it.
By their numbers in this assay, from the lowest: compound 3; then compound 1; then compound 2.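

Phenoxy on the sulfonyl sulfur gives a 560-fold lower number from compound 2 to compound 3 (2.75 log units; beyond the scatter) and a 22-fold lower number from compound 1 to compound 3 (1.35 log units; beyond the scatter) so the group held here can lower the number as well as raise it, whereas the earlier step showed only a rise. Compound 3 holds the lowest number of the three while keeping a phenyl ring, so that ring alone does not go with the high number of compound 2. Nothing available explains this result.

On these data alone, whether the phenyl ring or the linking oxygen matters more stays open. Methoxy or phenylamino on the sulfur would separate the two.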